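The compounds below may be only part of what the source reports. "The series", "measured", "known", "first", "only" and "open" are said of these compounds alone.

Working notes on the series. Compound 1 `C=CC1=C(C(=O)NCCCCC)C(c2ccc(F)cc2)OC1` and compound 2 `C=CC1=C(C(=O)NCc2ccc(Cl)cc2)C(c2ccc(F)cc2)OC1` share one core. In a functional assay on QGY7701 cells (Homo sapiens) for cytotoxicity, read by MTT assay, with a stated time of 24 h (on this read-out higher numbers stand for weaker inhibition and lower numbers for stronger inhibition), compound 1 reports only a limit, > 100000 nM, the assay limit (the limit of > 100000 nM in this assay, at which 1 of the 2 values shown sits). In this assay compound 2 gives 36900 nM, and the step is an at least 2.7-fold lower number from compound 1 to compound 2 (0.43 log units; beyond the scatter).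

Compound 3 `C=CC1=C(C(=O)O)C(c2ccc(F)cc2)OC1` is not yet measured; it differs from compound 1 by hydroxy in place of pentylamino on a carbonyl carbon. For the measured compounds named here, the only measured step, an at least 2.7-fold lower number from compound 1 to compound 2 (0.43 log units; beyond the scatter), swaps the group on the amide-type nitrogen and does not bear on this change, so no step beyond the scatter is expected in this assay, in either direction. Compound 3 is estimated at 150000 nM, range 40000 nM to 600000 nM. The expected step is a step that the limit leaves unreadable from compound 1 to compound 3.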

Compound 3, half-maximal inhibitory concentration: > 100000 nM
Compound 3 ended at the assay's limit; the forecaster's own chance of this, stated with the estimate: 70%; the middle value does not contradict the limit.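

Compound 1 and compound 3 both stand at the assay limit, so no new step can be read between them: the limit of > 100000 nM in this assay, at which 2 of the 3 values shown sit.

From the compounds shown here alone, how hydroxy and pentylamino on the carbonyl carbon compare stays open.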